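The compounds below may be only part of what the source reports. "The series", "measured", "known", "first", "only" and "open" are said of these compounds alone.

Compound 1 `CC[C@H]1c2cc(Cl)ccc2C(=O)N1c1cncc2c1CCC[C@H]2NC(C)=O` belongs to a small set of three measured compounds tested in an ADME assay on cells for inhibition of cytochrome P450 11B1, mitochondrial (Homo sapiens), read by HTRF; on this read-out lower numbers stand for stronger inhibition and higher numbers for weaker inhibition. In this assay compound 1 gives 3630 nM. Among the three numbers this is the second highest. Compound 3 `CCC(=O)N[C@@H]1CCCc2c1cncc2N1C(=O)c2ccc(Cl)cc2[C@@H]1C` gives 414 nM, a lower number that sits beyond the usual scatter from compound 1, so compound 3 is the stronger inhibitor of the pair. Compound 2 `O=C1c2ccc(Cl)cc2C(C2CC2)N1c1cccnc1` gives 32500 nM, a higher number, again beyond the scatter, so compound 2 is weaker than compound 1.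

Compound 4 `CC[C@@H]1c2cc(Cl)ccc2C(=O)N1c1cncc2c1CCC[C@H]2NC(C)=O` has not yet been measured. It differs from compound 1 as follows: the two compounds have the same atoms and bonds and differ only in configuration as drawn: 1 of 2 stereo elements differ; a stereocentre at a saturated ring carbon is drawn S in compound 1 and R in compound 4. The two compounds are otherwise identical, so any difference in the result would come from the drawn configuration alone. Within the data shown here, no measured pair in this set shows the effect of such a change, so its size and direction are open. Compound 4 is estimated at 2500 nM, within a range of 300 nM to 20000 nM, which corresponds to an expected step of a 1.5-fold lower number from compound 1 to compound 4 (0.16 log units; within the scatter).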

Compound 4, half-maximal inhibitory concentration: 334 nM
Compound 4: middle estimate off by 7.5-fold (0.87 log units), on the high side; measured number inside the range.
By their numbers in this assay, from the lowest: compounds 4 and 3 (each within the scatter of the next); then compound 1; then compound 2.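

In this assay, redrawing this saturated ring carbon from S to R gives an 11-fold lower number from compound 1 to compound 4 (1.04 log units; beyond the scatter), a large change and the first in this set that can be read from a single difference. The earlier compounds shown here differ from one another in more than one place, so they could not show that this stereocentre alone can move the number so far. The step can be assigned to the drawn configuration because of the following: the fact that compounds 1 and 4 differ only in the configuration as drawn

Going by these compounds, the other stereo element is the same in compound 1 and compound 4, so the effect of changing it remains unknown. Also open, on these data alone, is whether the R drawing would give a step of similar size and direction with a longer chain or an amine on this stereocentre.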